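The source may report more compounds than this note shows. Statements on the series, on what has been measured and on what is new or still open speak of the compounds shown alone.

Two compounds have been measured in a functional assay on the whole organism (Ear) for inhibition, with Mus musculus as the target, with a stated time of 30 min, at a dose of 100 mg/kg by the intraperitoneal route; on this read-out higher numbers stand for more inhibition at the one dose given (going by the name of the read-out) and lower numbers for less inhibition:

Compound 1, `O=C(/C=C/c1ccc(/C=N/NC(=O)c2ccncc2)cc1)c1ccc(Br)cc1`, gives 55.7%.
Compound 2, `Cc1ccc(C(=O)/C=C/c2ccc(/C=N/NC(=N)N)cc2)cc1`, gives 77.7%.

Compound 2 stands highest of the two numbers; the nearest is compound 1, a number lower by a gap that lies beyond the usual scatter of this kind of measurement. Compound 3, `N=C(N)N/N=C/c1ccc(/C=C/C(=O)c2ccc(Br)cc2)cc1`, has not yet been measured in this assay. It differs from compound 2 at one place only: bromo in place of methyl on an aromatic carbon. Among the compounds with values here, compound 1 also carries the 4-bromophenyl group, but it differs from compound 2 and from compound 3 elsewhere as well, so no step between two measured compounds isolates the exchange of methyl for bromo, and the two measured values alone cannot show what this exchange does. With only the value of compound 2 to rest on, the account expects no step beyond the scatter in this assay, in either direction, from compound 2 to compound 3, the estimated step being a number 3.7 percentage points lower from compound 2 to compound 3 (within the scatter). Compound 3 is therefore estimated at 74%, with a range from 52% to 90%.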

Compound 3, a percentage reported as inhibition, in the whole organism at one dose (the size of the read-out at that dose, not a potency): 68.9%
The estimate for compound 3 lay 5.1 percentage points above the measured number; the range from low to high includes it.
By their numbers in this assay, from the lowest: compound 1; then compounds 3 and 2 (each within the scatter of the next).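

In this assay, bromo in place of methyl on an aromatic carbon, read as 4-methylphenyl to 4-bromophenyl, gives a number 8.8 percentage points lower from compound 2 to compound 3 (within the scatter), so at this position, at the one dose given, the two groups cannot be told apart. With the 4-bromophenyl group held fixed, the group on the amine nitrogen can now be read on its own: the group of 3 heavy atoms in place of the group of 8 heavy atoms with its six-membered aromatic ring gives a number 13.2 percentage points higher from compound 1 to compound 3 (beyond the scatter), and of the two changes only this modest one on the amine nitrogen moves the number beyond the scatter. No further measurement bears on why either step has the size it has.

On these data alone, what a methoxy group, a chloro group or a plain hydrogen would do on the same aromatic carbon stays open, as does whether such a group would move the number beyond the scatter. Also open, as far as these compounds go, is how a simple acetyl group or a benzoyl group on the amine nitrogen would compare with the two groups seen there.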